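A few compounds are considered here, and "the series" means these few. Any claim that something is new, unique, unknown or untested is made for them only; others in the source may bear on it.

Measured compounds:
Compound 1 `CCC(CC)O[C@@H]1C=C(B(O)O)C[C@H](NC(=N)N)[C@H]1NC(C)=O`: "not determined" (no result reported)
Compound 2 `CCC(CC)O[C@@H]1C=C([S+]([O-])O)C[C@H](N)[C@H]1NC(C)=O`: > 100000 nM

Among the measured compounds shown here, the only information on this series comes from an ADME assay on MDCK cells (Canis lupus familiaris) for cytotoxicity, with a stated time of 48 h; on this read-out lower numbers stand for higher toxicity in this test and higher numbers for lower toxicity in this test. In this assay, compound 2 gives > 100000 nM, and this is a limit of the assay, not a number. For compound 1, the entry reads "not determined" (no result reported), so it offers no comparison. the limit of > 100000 nM in this assay, at which 1 of the 2 values shown sits, is therefore the whole of the measured evidence.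

The next compound, compound 3 `CCC(CC)O[C@@H]1C=C([S+]([O-])O)C[C@H](NC(=N)N)[C@H]1NC(C)=O`, departs from compound 2 at a single place. Its change is a group of 3 heavy atoms (1 carbon, 2 nitrogen; no ring) in place of a hydrogen atom, on an amine nitrogen.

For the measured compounds named here, no measured pair shows what such a change does, so the size of the step cannot be drawn from earlier data. The expectation rests only on compound 2 and its limit of > 100000 nM. The expected a number no higher from compound 2 to compound 3 (the limit leaves the size open) in this assay is no change beyond the usual scatter, and the assay will probably again report only a limit. For compound 3 the estimated value is 100000 nM, with an expected range from 50000 nM to 200000 nM.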

Compound 3, half-maximal cytotoxic concentration: > 100000 nM
Compound 3: only a limit was reported; the forecaster's own chance of this, stated with the estimate: 85%; the middle value sits exactly at the limit.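

No step from compound 2 to compound 3 can be read, because both results in this assay are limits and not numbers: the limit of > 100000 nM in this assay, at which 2 of the 3 values shown sit.

The compounds shown leave open whether the new group on the amine nitrogen, in place of a hydrogen atom, changes the read-out in this assay at all.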